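Chloro to Trifluoromethyl: What to Expect for Compound 4

The compounds below may be only part of what the source reports. "The series", "measured", "known", "first", "only" and "open" are said of these compounds alone.

Measured in a functional assay on PC-12 cells (Rattus norvegicus) for cytotoxicity, read by MTT assay, with stated times of 2 h and 24 h, tested at 1 uM; on this read-out higher numbers stand for a stronger effect at the one concentration tested and lower numbers for a weaker effect:
Compound 1, `CCc1ccc(-n2nc(-c3ccc(C(F)(F)F)cc3O)nc2-c2ccccc2O)cc1`: 64.4%
Compound 2, `COc1ccccc1-n1nc(-c2ccc(C(F)(F)F)cc2O)nc1-c1ccccc1O`: 70.7%
Compound 3, `Oc1cc(C(F)(F)F)ccc1-c1nc(-c2ccccc2O)n(-c2cccc(Cl)c2)n1`: 72.3%

Compound 3 holds the largest of the three numbers, but the gaps to it are small: a number 7.9 percentage points higher from compound 1 to compound 3 (within the scatter) and a number 1.6 percentage points higher from compound 2 to compound 3 (within the scatter). The next compound, compound 4, `Oc1cc(C(F)(F)F)ccc1-c1nc(-c2ccccc2O)n(-c2cccc(C(F)(F)F)c2)n1`, differs from compound 3 in one place: trifluoromethyl in place of chloro on an aromatic carbon. The three measured steps each exchange the whole ring on the aromatic nitrogen, not a single group on an aromatic carbon, so none of them tests this particular change directly; all three, including a number 6.3 percentage points higher from compound 1 to compound 2 (within the scatter), stayed within the scatter. On that basis the step of a number 2.3 percentage points lower from compound 3 to compound 4 (within the scatter) is expected to be small, with no direction beyond the scatter. Compound 4 is therefore estimated at 70%, within a range of 58% to 82%.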

Compound 4, a percentage reported as activity, at one concentration (the size of the read-out at that concentration, not a potency): 71.5%
For compound 4 the middle estimate is 1.5 percentage points below the measured one; low and high end bracket the measured number.
By their numbers in this assay, from the lowest: compounds 1, 2, 4 and 3 (each within the scatter of the next).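

On this assay the exchange of chloro for trifluoromethyl, a single group on an aromatic carbon rather than a whole ring, comes out as a number 0.8 percentage points lower from compound 3 to compound 4 (within the scatter) even though 4 heavy atoms enter where 1 leaves. The 3-(trifluoromethyl)phenyl ring on the aromatic nitrogen also stays close to the other rings there, as a number 0.8 percentage points higher from compound 2 to compound 4 (within the scatter) and a number 7.1 percentage points higher from compound 1 to compound 4 (within the scatter) show. No measurement at hand bears on the reason for this result.

Going by these compounds, whether a group of another kind at this place, such as an amine or a carboxylic acid, would stay this close remains open. So does how these compounds compare at any other concentration.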